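This account rests on a few compounds, and the source may have more. Where it says the series, first, only, none or still open, it means among the compounds named here.

Measured so far in an assay on isolated protein (strain Sprague-Dawley) for inhibition of Amine oxidase [flavin-containing] B (Rattus norvegicus), read by spectrophotometry, with a stated time of 5 min; on this read-out higher numbers stand for weaker inhibition and lower numbers for stronger inhibition:

Compound 1, `O=c1cc(O)c2ccc(OCc3cccc(F)c3)cc2o1`, gives 2090 nM.
Compound 2, `O=c1cc(Oc2ccccc2)c2ccc(OCc3cccc(Cl)c3)cc2o1`, gives 4070 nM.

Of these two numbers, compound 2 has the higher one, yet its gap to compound 1 lies within the scatter of repeated measurements, so the two values cannot be told apart with any confidence. Among the compounds with values here, the two compounds also differ in more than one place, so no single step between them can be read off.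

Compound 3, `O=Cc1cc(=O)oc2cc(OCc3cccc(Cl)c3)ccc12`, has not yet been measured. Set against compound 2 the change is formyl in place of phenoxy on an aromatic carbon of the shared core; the rest of the molecule is kept.

Within the data shown here, no measured step of this kind exists here, so the expectation rests only on the two values above. The account expects the step of a 1.6-fold lower number from compound 2 to compound 3 (0.21 log units; within the scatter) to stay within the scatter, with a slight lean toward a lower number. Compound 3 is therefore estimated at 2500 nM, with a range from 600 nM to 10000 nM.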

Compound 3, half-maximal inhibitory concentration: 52.5 nM
The estimate for compound 3 lay 48-fold (1.68 log units) above the measured number; measured number below the stated range.
By their numbers in this assay, from the lowest: compound 3; then compounds 1 and 2 (each within the scatter of the next).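

In this assay, putting formyl in place of phenoxy on the aromatic carbon opposite the ring oxygen gives a 78-fold lower number from compound 2 to compound 3 (1.89 log units; beyond the scatter). Within the data shown here, this is the first single change that can be read, and it shows that the group at this position can strongly alter the number, which compounds 1 and 2 could not show because they differ in more than one place. The change removes a six-membered aromatic ring of carbon only and brings in a double bond outside aromatic rings, while the hydrogen-bond acceptor count and the lack of net charge stay the same, and nothing measured here accounts for the size of the step.

The compounds shown leave open whether the step comes from the presence of formyl or from the loss of phenoxy, and compound 1 cannot settle this, as it differs from compound 3 both at this position and in carrying fluorine rather than chlorine. A methyl group, a nitrile or a carboxylic acid at the same position, with the rest of compound 3 kept, would help separate these two readings.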